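Working notes on tolerated concentration, compound 3 to compound 4

A few compounds are considered here, and "the series" means these few. Any claim that something is new, unique, unknown or untested is made for them only; others in the source may bear on it.

The shared core appears in compound 1 `COc1ccc2[nH]c(C(=O)N3CC(=O)N(Cc4ccccc4)[C@@H](CN4CCC(C)CC4)C3)cc2c1`, compound 2 `COc1ccc2[nH]c(C(=O)N3CC(=O)N(Cc4ccccc4)[C@@H](Cc4ccccn4)C3)cc2c1` and compound 3 `COc1ccc2[nH]c(C(=O)N3CC(=O)N(Cc4ccccc4)[C@@H](CN4C(=O)c5ccccc5C4=O)C3)cc2c1`. In an ADME assay on Vero cells (Chlorocebus sabaeus) for cytotoxicity, with a stated time of 7 days (a lower number here means that less compound is tolerated, a higher number that more compound is tolerated), compound 1 gives > 30000 nM, which is a limit of the assay. Compound 2 gives > 30000 nM, again a limit. Among the compounds with values here, compound 3 gives 41000 nM, the only number among the three values shown. Compound 4 `COc1ccc2[nH]c(C(=O)N3CC(=O)N(Cc4ccccc4)[C@@H](CN4CCc5ccccc5C4)C3)cc2c1` carries a group of 10 heavy atoms (9 carbon, 1 nitrogen; one six-membered non-aromatic ring with 1 hetero atom, one six-membered aromatic ring of carbon only) in place of a group of 11 heavy atoms (8 carbon, 1 nitrogen, 2 oxygen; one five-membered non-aromatic ring with 1 hetero atom, one six-membered aromatic ring of carbon only), on a saturated chain carbon bound to a saturated ring carbon. The steps a step that the limit leaves unreadable from compound 1 to compound 3 and a step that the limit leaves unreadable from compound 2 to compound 3 bear on this exchange, but their sizes cannot be read because of the limit of > 30000 nM in this assay, at which 2 of the 3 values shown sit. No readable step is therefore available to set a direction. The step of a 1.0-fold lower number from compound 3 to compound 4 (0.01 log units; within the scatter) is expected to stay within the usual scatter. Compound 4 is estimated at 40000 nM, with a range from 20000 nM to 80000 nM.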

Compound 4, half-maximal cytotoxic concentration: 51800 nM
The estimate for compound 4 lay 1.3-fold (0.11 log units) below the measured number, and the stated range covers the measured number.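

In this assay, this place, on a saturated chain carbon bound to a saturated ring carbon, now has its first readable step (a 1.3-fold higher number from compound 3 to compound 4 (0.10 log units; within the scatter)). 1,2,3,4-Tetrahydroisoquinolin-2-yl, which has no double bonds outside aromatic rings, and the carbonyl-bearing group it replaces give values within the scatter of each other. The steps from compound 1 and compound 2 to compound 4 cannot be read because of a limit: the limit of > 30000 nM in this assay, at which 2 of the 4 values shown sit. On these data alone, how a carboxylic acid or a primary amine at this place would read in this assay remains open.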